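The compounds below may be only part of what the source reports. "The series", "measured", "known", "first", "only" and "open" are said of these compounds alone.

Of the compounds shown here, two have been measured. Compound 1 `N#CC1=C(N)Oc2c(N)cc3nc4ccccc4nc3c2C12C(=O)N(Cc1cnnn1-c1cccc(Br)c1)c1ccccc12` gives 26100 nM in a functional assay on HCT-116 cells (Homo sapiens) for antiproliferative activity, read by MTT assay, with a stated time of 48 h; on this read-out higher numbers stand for weaker inhibition and lower numbers for stronger inhibition. Compound 2 `Cc1cc(C)cc(-n2nncc2CN2C(=O)C3(C(C#N)=C(N)Oc4c(N)cc5nc6ccccc6nc5c43)c3ccccc32)c1` reaches only the limit of the assay in this assay, > 50000 nM, so no number is known for it. For the measured compounds named here, the one measured step, an at least 1.9-fold higher number from compound 1 to compound 2 (0.28 log units; that floor lies within the scatter), is a change of 3,5-dimethylphenyl in place of 3-bromophenyl on an aromatic nitrogen; its size cannot be pinned down because the limit of > 50000 nM in this assay, at which 1 of the 2 values shown sits, caps it.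

Compound 3 `N#CC1=C(N)Oc2c(N)cc3nc4ccccc4nc3c2C12C(=O)N(Cc1cnnn1-c1ccc([N+](=O)[O-])cc1[N+](=O)[O-])c1ccccc12` differs from compound 2 by 2,4-dinitrophenyl in place of 3,5-dimethylphenyl on an aromatic nitrogen. Going by the values given here, the step bearing on it is the one from compound 1 to compound 2, which shows that exchanging one aryl group on that nitrogen did not move the number below the limit. Nothing measured shows that a second exchange on the same nitrogen would do more. The step of an at least 1.1-fold lower number from compound 2 to compound 3 (0.04 log units; that floor lies within the scatter) is therefore expected to stay within the scatter, in no firm direction. Compound 3 is expected to give 45000 nM, with a range from 15000 nM to 120000 nM.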

Compound 3, half-maximal inhibitory concentration: 23900 nM
The estimate for compound 3 lay 1.9-fold (0.27 log units) above the measured number; measured number inside the range.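

For the compounds shown here, the aryl group on this aromatic nitrogen of the five-membered ring can shift the read-out in this assay: 2,4-dinitrophenyl in place of 3,5-dimethylphenyl gives an at least 2.0-fold lower number from compound 2 to compound 3 (0.32 log units; beyond the scatter), the only step at this position printed as beyond the scatter. That figure is a floor and not a measured size, because the step starts from a value that is not a number: the limit of > 50000 nM in this assay, at which 1 of the 3 values shown sits. The two groups that give numbers cannot be told apart, with a 1.1-fold lower number from compound 1 to compound 3 (0.04 log units; within the scatter), so 2,4-dinitrophenyl and 3-bromophenyl stand level here even though they differ in heavy atoms and hydrogen-bond acceptors, and among these three compounds only 3,5-dimethylphenyl leaves the read-out at the limit.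

On these data alone, how far 3,5-dimethylphenyl really lies from the other two groups remains unknown, and three aryl groups do not show which feature of the ring governs the read-out. As far as these compounds go, it also remains open whether a plain phenyl, or a phenyl carrying an amine or a carboxylic acid, would stay level with compound 1 and compound 3 or move clearly away from them.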